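The compounds below may be only part of what the source reports. "The series", "measured", "known", "first", "only" and "open" are said of these compounds alone.

Compound 3 `COc1cc(Cl)cc(-c2nn(-c3cccc(NC(=O)Nc4ccc(Cl)c(Cl)c4)c3)cc2-c2ccncc2)c1` shows 5.72% in a functional assay on NCI-H23 cells (Homo sapiens) for inhibition, read by sulforhodamine B assay, with a stated time of 48 h, tested at 10 uM (on this read-out lower numbers stand for a stronger effect and higher numbers for a weaker effect at the one concentration tested), the highest of the three numbers measured. Compound 1 `COc1cc(Cl)cc(-c2nn(-c3cccc(NC(=O)Nc4ccc(Cl)c(C(F)(F)F)c4)c3)cc2-c2ccncc2)c1` gives 0.3% in this assay, within the scatter of compound 3, while compound 2 `COc1cc(Cl)cc(-c2nn(-c3cccc(NC(=O)Nc4cc(C(F)(F)F)cc(C(F)(F)F)c4)c3)cc2-c2ccncc2)c1` gives -6.14%, beyond the scatter below compound 3. Compound 4 `COc1cc(Cl)cc(-c2nn(-c3cccc(NC(=O)Nc4cccc(C(F)(F)F)c4)c3)cc2-c2ccncc2)c1` differs from compound 3 by 3-(trifluoromethyl)phenyl in place of 3,4-dichlorophenyl on an amide-type nitrogen. Within the data shown here, the one measured step that bears on this exchange is a number 5.4 percentage points higher from compound 1 to compound 3 (within the scatter), which replaced a trifluoromethyl by a chloro and moved the read-out only within the scatter. Reversing that direction and also removing a chloro is therefore expected to shift this assay little, if at all: compound 4 is expected to show 2% (range -10% to 14%), a step of a number 3.7 percentage points lower from compound 3 to compound 4 (within the scatter) that is expected to stay within the scatter.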

Compound 4, a percentage reported as activity, at one concentration (the size of the read-out at that concentration, not a potency): -5.1%
For compound 4 the middle estimate is 7.1 percentage points above the measured one; the range from low to high includes it.
By their numbers in this assay, from the lowest: compounds 2, 4, 1 and 3 (each within the scatter of the next, the first and the last beyond it).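

In this assay, the exchange of 3,4-dichlorophenyl for 3-(trifluoromethyl)phenyl on the amide-type nitrogen passes the usual scatter (a number 10.8 percentage points lower from compound 3 to compound 4 (beyond the scatter)), although only modestly, which the earlier step at this ring did not do. Removing a single ring substituent matters little here, whether hydrogen replaces trifluoromethyl (a number 1 percentage points higher from compound 2 to compound 4 (within the scatter)) or chloro (a number 5.4 percentage points lower from compound 1 to compound 4 (within the scatter)). No measurement at hand explains these numbers. Still open, from the compounds shown here alone, is how this ring would fare carrying an amine or a carboxylic acid in place of these halogen-bearing groups.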